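This account rests on a few compounds, and the source may have more. Where it says the series, first, only, none or still open, it means among the compounds named here.

- Compound 1 `Nc1ccc(-c2cn([C@@H]3CN[C@H](C(=O)Nc4ccc(Cl)c(C(F)(F)F)c4)C3)nn2)cn1`: 10400 nM
- Compound 2 `O=C(Nc1ccc(-c2cn([C@@H]3CN[C@H](C(=O)Nc4ccc(Cl)c(C(F)(F)F)c4)C3)nn2)cn1)C1CC1`: 8770 nM

In a functional assay on K562 cells (Homo sapiens) for inhibition, read by MTT assay, with a stated time of 48 h (on this read-out higher numbers stand for weaker inhibition and lower numbers for stronger inhibition), compound 1 gives 10400 nM and compound 2 gives 8770 nM, two values within the scatter of each other. Compound 3 `CC(C)(C)C(=O)Nc1ccc(-c2cn([C@@H]3CN[C@H](C(=O)Nc4ccc(Cl)c(C(F)(F)F)c4)C3)nn2)cn1` differs from compound 2 by tert-butyl in place of cyclopropyl on a carbonyl carbon. Among the compounds with values here, no measured step covers this exchange directly. The nearest one, a 1.2-fold lower number from compound 1 to compound 2 (0.07 log units; within the scatter), came with cyclopropylcarbonyl in place of hydrogen on a nitrogen on an aromatic ring. No change beyond the scatter is therefore expected, and the estimated step is a 1.1-fold lower number from compound 2 to compound 3 (0.04 log units; within the scatter). For compound 3 the expected value is 8000 nM, with an estimated range of 4000 nM to 16000 nM.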

Compound 3, half-maximal inhibitory concentration: 43800 nM
Beside the measured number, compound 3's estimate is 5.5-fold (0.74 log units) below it, outside the stated range (above it).
By their numbers in this assay, from the lowest: compounds 2 and 1 (each within the scatter of the next); then compound 3.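

In this assay the group on the carbonyl carbon matters, since tert-butyl in place of cyclopropyl gives a 5.0-fold higher number from compound 2 to compound 3 (0.70 log units; beyond the scatter). Putting an acyl group on this nitrogen does not by itself fix the outcome: compound 1 and compound 2 stand within the scatter of each other, whereas (tert-butyl)carbonyl in place of hydrogen gives a 4.2-fold higher number from compound 1 to compound 3 (0.62 log units; beyond the scatter). No available evidence bears on what lies behind these steps. The compounds shown leave open where methyl, isopropyl or a phenyl ring on the carbonyl carbon would fall relative to cyclopropyl and tert-butyl.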